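Swapping the Aryl Ring on a Shared Cyano Core

A few compounds are considered here, and "the series" means these few. Any claim that something is new, unique, unknown or untested is made for them only; others in the source may bear on it.

Measured so far:
compound 1 `CC(C)c1ccc(Nc2nc(SCc3cn(CC(=O)NC(=O)Nc4ccccn4)nn3)nc(-c3ccc(C(C)C)cc3)c2C#N)cc1` — 28600 nM
compound 2 `COc1cc(-c2nc(SCc3cn(CC(=O)NC(=O)Nc4ccccn4)nn3)nc(Nc3ccc(C(C)C)cc3)c2C#N)cc(OC)c1OC` — 30900 nM

Both compounds were tested in a functional assay on MCF7 cells (Homo sapiens) for inhibition, read by MTT assay, with a stated time of 72 h; on this read-out higher numbers stand for weaker inhibition and lower numbers for stronger inhibition. Compound 1 gives 28600 nM there, and compound 2 gives 30900 nM. Compound 2 thus carries the higher of the two numbers, but the step of a 1.1-fold higher number from compound 1 to compound 2 (0.03 log units; within the scatter) lies within the scatter, so the two cannot be told apart on these data.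

The next compound, compound 3 `Cc1ccc(-c2nc(SCc3cn(CC(=O)NC(=O)Nc4ccccn4)nn3)nc(Nc3ccc(C(C)C)cc3)c2C#N)cc1`, has not yet been measured. It differs from compound 2 in one place: 4-methylphenyl in place of 3,4,5-trimethoxyphenyl on an aromatic carbon. Among the measured compounds shown here, the only measured step that bears on this position is the one from compound 1 to compound 2, where the aryl ring was swapped and the number moved by a 1.1-fold higher number from compound 1 to compound 2 (0.03 log units; within the scatter). Since exchanging one aryl ring for another at this position changed nothing beyond the scatter, a further swap to 4-methylphenyl is expected to do the same, giving an expected step of a 1.1-fold lower number from compound 2 to compound 3 (0.03 log units; within the scatter). Compound 3 is therefore estimated at 29000 nM, with a likely range from 12000 nM to 70000 nM.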

Compound 3, half-maximal inhibitory concentration: > 64000 nM
Compound 3: no number, only a limit; the forecaster's own chance of this, stated with the estimate: 15%; middle value at least 2.2-fold (0.34 log units) from the limit.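

In this assay compound 3 has no number, only a limit: the limit of > 64000 nM in this assay, at which 1 of the 3 values shown sits. Replacing 3,4,5-trimethoxyphenyl with 4-methylphenyl gives an at least 2.0-fold higher number from compound 2 to compound 3 (0.31 log units; beyond the scatter), so this position is not indifferent to the aryl ring it carries, as the first swap alone might have suggested. Changing isopropyl to methyl on the same ring gives an at least 2.2-fold higher number from compound 1 to compound 3 (0.34 log units; beyond the scatter), so even an edit confined to one small ring substituent is enough to weaken inhibition in this series, although the aryl rings of compound 1 and compound 2 could not be told apart.

From the compounds shown here alone, the true size of both new steps stays open, as each rests on a limit and gives only a lower bound. Going by these compounds, it is also open whether the 4-methylphenyl result reflects the length of the ring substituent or something else, and a ring bearing an ethyl group, a methoxy group or an amine at that spot would be needed to tell how inhibition tracks the group there.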